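A few compounds are considered here, and "the series" means these few. Any claim that something is new, unique, unknown or untested is made for them only; others in the source may bear on it.

- Compound 1 `Cc1oc(-c2c(C)c(C)c(C)c(C)c2C)nc1CN1CCC(C(=O)NCCCN2C[C@H](C)C[C@H](C)C2)CC1`: 455 10^-6 cm/s
- Compound 2 `Cc1cccc(C)c1-c1nc(CN2CCC(C(=O)NCCCN3C[C@H](C)C[C@H](C)C3)CC2)c(C)o1`: 254 10^-6 cm/s

In a physicochemical assay for permeability, using PAMPA (a higher number here means that the compound crosses the layer faster, a lower number that the compound crosses the layer more slowly), compound 2 gives 254 10^-6 cm/s, which lies within the scatter of compound 1. Compound 3 `Cc1cc(C)cc(-c2nc(CN3CCC(C(=O)NCCCN4C[C@H](C)C[C@H](C)C4)CC3)c(C)o2)c1` has the same atoms as compound 2, joined differently, with 3,5-dimethylphenyl in place of 2,6-dimethylphenyl on an aromatic carbon. Within the data shown here, the only measured step that alters this group is a 1.8-fold lower number from compound 1 to compound 2 (0.25 log units; within the scatter), with 2,6-dimethylphenyl in place of 2,3,4,5,6-pentamethylphenyl. In this assay no change beyond the scatter is therefore expected, and the estimated step is a 1.1-fold higher number from compound 2 to compound 3 (0.04 log units; within the scatter). The expected value for compound 3 is 280 10^-6 cm/s, with an estimated range from 130 10^-6 cm/s to 560 10^-6 cm/s.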

Compound 3, apparent permeability: 864 10^-6 cm/s
Compound 3: the middle estimate sits 3.1-fold (0.49 log units) below what was measured; measured number above the stated range.
By their numbers in this assay, from the lowest: compounds 2, 1 and 3 (each within the scatter of the next, the first and the last beyond it).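

In this assay, rearranging the methyl groups without changing the atoms has a real effect: 3,5-dimethylphenyl in place of 2,6-dimethylphenyl gives a 3.4-fold higher number from compound 2 to compound 3 (0.53 log units; beyond the scatter). Among these compounds, replacing 2,3,4,5,6-pentamethylphenyl with 3,5-dimethylphenyl gives a 1.9-fold higher number from compound 1 to compound 3 (0.28 log units; within the scatter), so only the step between the two dimethylphenyl isomers clearly exceeds the usual variation. Nothing available explains this difference. From the compounds shown here alone, how an unsubstituted phenyl or a pyridine ring on this aromatic carbon would behave remains open. So does whether the same methyl rearrangement would have a similar effect on a different core.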